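This account rests on a few compounds, and the source may have more. Where it says the series, first, only, none or still open, it means among the compounds named here.

Compound 1 `CCCCN(C)c1nc(C)nc2c(-c3ccc(OC)nc3C)c(C)nn12` serves as the reference point. Going by the values given here, in an assay on cell membranes for displacement of a labelled ligand from corticotropin-releasing factor receptor 1 (Rattus norvegicus) (on this read-out lower numbers stand for stronger inhibition and higher numbers for weaker inhibition), compound 1 gives 8.1 nM; the only other compound measured, compound 2 `CCN(CC)c1nc(C)nc2c(-c3cnc(OC)cc3C)c(C)nn12`, gives 14.5 nM in this assay, and the two numbers lie within the usual scatter of each other, so neither stands apart. Compound 3 `CCN(CC)c1nc(C)nc2c(-c3ccc(OC)nc3C)c(C)nn12` carries diethylamino in place of butyl(methyl)amino on an aromatic carbon. Among the compounds with values here, no measured pair isolates this change. Compound 2 already bears diethylamino on the shared core, and its value 14.5 nM suggests the group is tolerated, so no step beyond the scatter is expected in this assay. Compound 3 is expected at 10 nM, with a range of 4 nM to 25 nM. The estimate corresponds to a step of a 1.2-fold higher number from compound 1 to compound 3 (0.09 log units; within the scatter).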

Compound 3, half-maximal inhibitory concentration: 12 nM
The estimate for compound 3 lay 1.2-fold (0.08 log units) below the measured number; the range from low to high includes it.
By their numbers in this assay, from the lowest: compounds 1, 3 and 2 (each within the scatter of the next).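

Compound 3 gives the first direct read on this position, on an aromatic carbon between two ring nitrogen atoms. In this assay, diethylamino in place of butyl(methyl)amino gives a 1.5-fold higher number from compound 1 to compound 3 (0.17 log units; within the scatter) and so the exchange of these two open-chain amino groups, with one heavy atom fewer in diethylamino, leaves the number within the scatter. No available measurement bears on why this is so.

On these data alone, whether this position also accepts a ring amine such as morpholine or a longer chain such as dibutylamino remains open.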